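Compound 1 to compound 3: methylsulfanyl for methyl

The source may report more compounds than this note shows. Statements on the series, on what has been measured and on what is new or still open speak of the compounds shown alone.

In an ADME assay on HEK293 cells (Homo sapiens) for inhibition, read by MTT assay, with a stated time of 48 h (a higher number here means a weaker inhibitor, a lower number a stronger inhibitor), compound 1 (`Cc1ccc(-c2nc3ccccn3c2Sc2ccccc2)cc1`) gives > 100000 nM as a limit of the assay and not a number. Compound 2 (`c1ccc(Sc2c(-c3cccc4ccccc34)nc3ccccn23)cc1`) gives > 100000 nM in this assay and this too is only a limit. For the measured compounds named here, compound 1 therefore has a limit rather than a measured position, and no step between measured compounds is available to show what size of change this series can produce.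

Compound 3 (`CSc1ccc(-c2nc3ccccn3c2Sc2ccccc2)cc1`) is still to be measured. It carries methylsulfanyl in place of methyl on an aromatic carbon, para to a large group (methylsulfanyl in place of methyl on an aromatic carbon). The same difference reads as 4-methylphenyl to 4-(methylsulfanyl)phenyl.

No step beyond the usual scatter is expected in this assay, in either direction. This expectation rests on compound 1 with its limit of > 100000 nM and on the wider picture (the limit of > 100000 nM in this assay, at which 2 of the 2 values shown sit). The estimated change is a number no higher from compound 1 to compound 3 (the limit leaves the size open) and no more than that. For compound 3 the estimated value is 100000 nM with an expected range from 30000 nM to 300000 nM and a report as a limit is the likeliest outcome.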

Compound 3, half-maximal inhibitory concentration: > 100000 nM
Compound 3 gave a limit, no number; the forecaster's own chance of this, stated with the estimate: 80%; the middle value lies on the limit itself.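

In this assay compound 3 gives > 100000 nM, a limit of the assay and not a number. Compound 1 is also reported only as a limit, so no step can be read between compound 1 and compound 3. For the compounds shown here, the series so far rests at one point: the limit of > 100000 nM in this assay, at which 3 of the 3 values shown sit. The compounds shown leave open what size of step this series can produce in this assay.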